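A few compounds are considered here, and "the series" means these few. Any claim that something is new, unique, unknown or untested is made for them only; others in the source may bear on it.

Measured compounds in a functional assay, read by fluorescence and spectrophotometry, with a stated time of 1 h; on this read-out lower numbers stand for an effect already at smaller amounts and higher numbers for an effect only at larger amounts of compound:
- compound 1, `CCCCCCCCCCS(=O)(=O)/C=C/c1ccc(O)c(O)c1`: 6800 nM
- compound 2, `O=S(=O)(/C=C/c1ccc(O)c(O)c1)CC1CCCO1`: 10500 nM
- compound 3, `CCCCCCCCCCCCS(=O)(=O)/C=C/c1ccc(O)c(O)c1`: 8500 nM

Compound 2 gives the highest of the three numbers in this assay, but its distances to the other two are small: compound 3 is nearest and compound 1 furthest, and both gaps lie within the scatter, so no order among the three can be read from these numbers. Compound 4, `O=S(=O)(/C=C/c1ccc(O)c(O)c1)CC1CCCC1`, is not yet measured. Its difference from compound 2 is cyclopentyl in place of oxolan-2-yl on a saturated chain carbon bound to a sulfonyl sulfur. Within the data shown here, the only measured step in the set is a 1.3-fold higher number from compound 1 to compound 3 (0.10 log units; within the scatter); it changes a chain far out from the sulfonyl sulfur and lies within the scatter. Among the measured compounds shown here, it therefore says little about a change on a saturated chain carbon bound to the sulfonyl sulfur, and no measured pair probes the exchange of oxolan-2-yl for cyclopentyl. What the three numbers do show is that the group on the sulfonyl side has so far moved the read-out only within the scatter, the oxolan-2-yl compound 2 included. The expectation for compound 4 is thus a step of a 1.3-fold lower number from compound 2 to compound 4 (0.12 log units; within the scatter), not beyond the scatter. Compound 4 is estimated at 8000 nM in this assay, with a range from 4000 nM to 16000 nM.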

Compound 4, half-maximal effective concentration: 9400 nM
Beside the measured number, compound 4's estimate is 1.2-fold (0.07 log units) below it, and the stated range covers the measured number.
By their numbers in this assay, from the lowest: compounds 1, 3, 4 and 2 (each within the scatter of the next).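

In this assay, cyclopentyl in place of oxolan-2-yl on a saturated chain carbon bound to a sulfonyl sulfur gives a 1.1-fold lower number from compound 2 to compound 4 (0.05 log units; within the scatter), the first step read at this place, as the earlier step lay further out along a chain. A ring with 1 hetero atom gives way here to a ring of carbon only, and 1 hydrogen-bond acceptor leaves, yet the read-out stays within the scatter, so this pair gives no sign that the ring oxygen of oxolan-2-yl matters in this assay. No evidence is at hand on what lies behind this result.

On these data alone, whether this place tolerates more than this one exchange stays open: an amine, a carboxylic acid or a phenyl ring in place of the five-membered ring could still move the read-out beyond the scatter, and the pair says nothing about them. The shared core is the same in all the compounds shown, so what a methoxy group in place of a hydroxyl group there would do also stays open.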